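Rearranging the ketone chain of compound 2

The source may hold more compounds than are shown below. What is called first, only, known or untested is meant among the compounds shown, and "the series" means these compounds.

The series was examined in an assay on HEK293 cells for positive allosteric modulation of metabotropic glutamate receptor 3 (Rattus norvegicus), read by thallium flux, with a stated time of 2.5 min; on this read-out lower numbers stand for smaller maximal responses and higher numbers for larger maximal responses. Compound 1 `Cc1c(OCCCCOc2ccc(C(=O)O)cc2Cl)ccc(C(=O)CC2CCCC2)c1O` gives 27.4% in this assay. Compound 2 `CCCC(=O)c1ccc(OCCCCOc2ccc(C(=O)O)cc2C)c(C)c1O` gives 40.5% in this assay. Compound 3 `Cc1c(OCCCCOc2cccc(C(=O)O)c2)ccc(C(=O)CC(C)C)c1O` gives 69.9% in this assay. Among these three numbers compound 2 stands second highest: the nearest is compound 1, which lies below it by more than the usual scatter, and the furthest is compound 3, which lies above it by more than the usual scatter.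

Compound 4 `Cc1cc(C(=O)O)ccc1OCCCCOc1ccc(C(=O)C(C)C)c(O)c1C` is a rearrangement of compound 2 with the same atoms joined differently: isopropyl in place of propyl on a carbonyl carbon. The two share everything else, and the change is the only one between them. Among the measured compounds shown here, no pair of measured compounds differs in a single place, so the size of such a step has not been observed here.

The step of a number 0.5 percentage points lower from compound 2 to compound 4 (within the scatter) is expected to be small, with no direction favoured beyond the scatter. Compound 4 is therefore expected to give about 40% in this assay, between 25% and 58%.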

Compound 4, largest response reached (reported as percent of maximum), in percent of the reference or control that the assay uses: 25.2%
Beside the measured number, compound 4's estimate is 14.8 percentage points above it, within the range that was stated.
By their numbers in this assay, from the lowest: compounds 4 and 1 (each within the scatter of the next); then compound 2; then compound 3.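

Among the compounds shown here, replacing propyl with isopropyl on a carbonyl carbon gives the first single-change step: in this assay it is a number 15.3 percentage points lower from compound 2 to compound 4 (beyond the scatter) and is the only such step that can be read here. The two groups have the same count of carbon atoms, and neither brings a ring, a hydrogen-bond donor or acceptor, or a net charge, so at this position a change in how the chain is joined is enough to shift the maximal response beyond the scatter. Nothing available here accounts for this drop.

The compounds shown leave open how a tert-butyl, a cyclopropyl or a longer chain such as pentyl on this carbonyl carbon would read out. They also leave open whether the same exchange would give a similar step with the other substituents on the benzoic acid ring.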